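A few compounds are considered here, and "the series" means these few. Any claim that something is new, unique, unknown or untested is made for them only; others in the source may bear on it.

The measured compounds are compound 1 `Fc1ccc(/C=C\c2cc3ccccc3nc2Cl)cc1`, compound 2 `Fc1ccc(/C=C\c2cc3ccc(Cl)cc3nc2Cl)cc1` and compound 3 `FC(F)(F)c1cc(/C=C\c2cc3ccccc3nc2Cl)cc(C(F)(F)F)c1`. In a functional assay on MDA-MB-231 cells (Homo sapiens) for antiproliferative activity, read by sulforhodamine B assay, with a stated time of 72 h (a higher number here means a weaker inhibitor, a lower number a stronger inhibitor), compound 1 gives 24000 nM, compound 2 gives 42600 nM and compound 3 gives 10100 nM, the lowest of the three. Compound 4 `FC(F)(F)c1cc(/C=C\c2cc3ccc(Cl)cc3nc2Cl)cc(C(F)(F)F)c1` has not been measured. The change from compound 1 to compound 2 is chloro in place of hydrogen on an aromatic carbon, and the change from compound 3 to compound 4 is chloro in place of hydrogen on an aromatic carbon; the two are the same change, made at the same place on the shared core. How the core of compound 3 differs from the core of compound 1 is not broken down here. In this assay the earlier instance made a 1.8-fold higher number from compound 1 to compound 2 (0.25 log units; within the scatter). The step from compound 3 to compound 4 is expected to be of like size, a 1.5-fold higher number from compound 3 to compound 4 (0.17 log units; within the scatter), because the earlier instance gave a 1.8-fold higher number from compound 1 to compound 2 (0.25 log units; within the scatter). Compound 4 is expected to give 15000 nM, with a range from 7000 nM to 35000 nM.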

Compound 4, half-maximal inhibitory concentration: > 50000 nM
Compound 4 was reported as a limit (the forecaster's own chance of this, stated with the estimate: 5%); at least 3.3-fold (0.52 log units) between middle value and limit.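

In this assay, chloro in place of hydrogen on an aromatic carbon gave an at least 4.9-fold higher number from compound 3 to compound 4 (0.69 log units; beyond the scatter), so the change did not carry over at a like size from one core to the other: the same change on two cores in this assay, a 1.8-fold higher number (0.25 log units; within the scatter) from compound 1 to compound 2 and an at least 4.9-fold higher number (0.69 log units; beyond the scatter) from compound 3 to compound 4, at least 2.7-fold (0.44 log units) apart, beyond the scatter of two such steps. Compound 4 gives > 50000 nM, which is a limit of the assay and not a number: the limit of > 50000 nM in this assay, at which 1 of the 4 values shown sits. This shows that the step differs between the two cores, but it does not show the full size of the step on the core of compound 3, and two instances give no rule for other cores in the series.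

The compounds shown leave open whether a methyl, a methoxy group or an amine at that same place would behave as chloro does. They also leave open how such groups would fare on each of the two cores.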